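From thiophen-2-yl to 2,5-dimethylthiophen-3-yl

A few compounds are considered here, and "the series" means these few. Any claim that something is new, unique, unknown or untested is made for them only; others in the source may bear on it.

In a functional assay on cells (Cancer cell lines, Homo sapiens) for inhibition (a lower number here means a stronger inhibitor of growth, a higher number a weaker inhibitor of growth), compound 3 (`N=C(N)N/N=C/c1c(-c2cccs2)nc2sccn12`) gives 25700 nM. Compound 2 (`N=C(N)N/N=C/c1c(-c2ccsc2)nc2sccn12`) gives 28800 nM, and compound 1 (`Cc1cc(-c2nc3sc(C)cn3c2/C=N/NC(=N)N)c(C)s1`) gives 18200 nM. Compound 3 thus lies within the scatter of both others, and the numbers give it no separate place.

Compound 4 (`Cc1cc(-c2nc3sccn3c2/C=N/NC(=N)N)c(C)s1`) has not yet been measured. It differs from compound 3 by 2,5-dimethylthiophen-3-yl in place of thiophen-2-yl on an aromatic carbon, with 2,5-dimethylthiophen-3-yl in place of thiophen-2-yl on an aromatic carbon. Within the data shown here, only one measured step bears on this site: a 1.1-fold lower number from compound 2 to compound 3 (0.05 log units; within the scatter), a change of thiophene attachment alone. Among the measured compounds shown here, no measured step isolates the two added methyl groups. Compound 1 carries the same 2,5-dimethylthiophen-3-yl, though it also differs from compound 4 in the core, and compound 1 with 18200 nM stays close to the other two values. A change a 1.3-fold lower number from compound 3 to compound 4 (0.11 log units; within the scatter) is therefore expected, and it is not expected to exceed the scatter. For compound 4 the estimated value is 20000 nM, with an expected range of 11000 nM to 36000 nM.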

Compound 4, concentration for total growth inhibition: 30200 nM
For compound 4 the middle estimate is 1.5-fold (0.18 log units) below the measured one; measured number inside the range.
By their numbers in this assay, from the lowest: compounds 1, 3, 2 and 4 (each within the scatter of the next).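

Across these four compounds, this assay does not respond to the two methyl groups on the thiophene: 2,5-dimethylthiophen-3-yl gives a 1.2-fold higher number from compound 3 to compound 4 (0.07 log units; within the scatter) against thiophen-2-yl and a 1.0-fold higher number from compound 2 to compound 4 (0.02 log units; within the scatter) against thiophen-3-yl. Among these compounds, compound 4 also gives the first step that isolates the methyl on the core, hydrogen in its place giving a 1.7-fold higher number from compound 1 to compound 4 (0.22 log units; within the scatter) and thus no separation from compound 1 either. Nothing further is available to bear on these results.

The compounds shown leave open whether anything at this aromatic carbon can move the number beyond the scatter, since every group here is a thiophene with or without methyl. An amine or a carboxylic acid on that thiophene, or a phenyl ring in its place, would test this.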